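From isopentyl to cyclopentyl on the shared core

The source may report more compounds than this note shows. Statements on the series, on what has been measured and on what is new or still open speak of the compounds shown alone.

Compound 1 `CC(C)CCCOc1cccc(O)c1C(=O)/C=C/c1ccc(O)cc1`: 3600 nM
Compound 2 `CC(C)=CCOc1cccc(O)c1C(=O)/C=C/c1ccc(O)cc1`: > 30000 nM (a limit of the assay)

Within the data shown here, in a functional assay on PC-3 cells (Homo sapiens) for antiproliferative activity, read by sulforhodamine B assay (a lower number here means a stronger inhibitor of growth, a higher number a weaker inhibitor of growth), compound 1 gives 3600 nM, the only exact number available so far. Compound 2 is reported as > 30000 nM, which is a limit of the assay and not a number.

Compound 3 `O=C(/C=C/c1ccc(O)cc1)c1c(O)cccc1OCC1CCCC1` is the next to be considered. It differs from compound 1 as follows: cyclopentyl in place of isopentyl on a saturated chain carbon bound to an oxygen on an aromatic ring. In words, cyclopentyl stands in place of isopentyl on a saturated chain carbon bound to an oxygen on an aromatic ring.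

Among the measured compounds shown here, one measured step bears on this place: an at least 8.3-fold higher number from compound 1 to compound 2 (0.92 log units; beyond the scatter). It brought in 2-methylprop-1-en-1-yl rather than cyclopentyl, so it is only a loose guide. Since that step from compound 1 was large, some loss of growth inhibition in this assay is expected for the new group too, though a smaller one. The expected change is a 1.4-fold higher number from compound 1 to compound 3 (0.14 log units; within the scatter). For compound 3 the estimated value is 5000 nM, with an expected range from 1800 nM to 20000 nM.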

Compound 3, concentration for 50% growth inhibition: 3040 nM
Beside the measured number, compound 3's estimate is 1.6-fold (0.22 log units) above it; measured number inside the range.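

Cyclopentyl serves at this place as well as isopentyl in this assay (a 1.2-fold lower number from compound 1 to compound 3 (0.07 log units; within the scatter)), with the difference within the scatter, so closing the group into a five-membered ring of carbon only leaves the growth inhibition of compound 1 unchanged. The loss seen earlier is therefore not a general result of replacing isopentyl on a saturated chain carbon bound to an oxygen on an aromatic ring, as the cyclopentyl group restores the inhibition lost with 2-methylprop-1-en-1-yl (an at least 9.8-fold lower number from compound 2 to compound 3 (0.99 log units; beyond the scatter)), and among the three compounds only compound 2 stands apart. Compound 2 is held at a limit of the assay and not at a number: the limit of > 30000 nM in this assay, at which 1 of the 3 values shown sits.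

The compounds shown leave open whether this tolerance extends to other groups at this place, such as a cyclohexyl ring, a longer chain or an amine. They also cannot separate the double bond of the 2-methylprop-1-en-1-yl group from the rest of that group as the feature that goes with the loss in compound 2.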